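A few compounds are considered here, and "the series" means these few. Any claim that something is new, unique, unknown or untested is made for them only; others in the source may bear on it.

In an ADME assay on MCF7 cells (Homo sapiens) for cytotoxicity, with a stated time of 72 h (on this read-out higher numbers stand for weaker inhibition and lower numbers for stronger inhibition), compound 2 `COc1ccccc1CNc1ncnc2c1ncn2C1CCCCO1` gives > 100000 nM, which is a limit of the assay and not a number. Compound 1 `Oc1cccc(CNc2ncnc3c2ncn3C2CCCCO2)c1` gives > 100000 nM, and this too is a limit. All the evidence so far therefore comes down to one observation: the limit of > 100000 nM in this assay, at which 2 of the 2 values shown sit.

Compound 3 `COc1cccc(CNc2ncnc3c2ncn3C2CCCCO2)c1` keeps the shared core and has the same atoms as compound 2, joined differently: 3-methoxyphenyl in place of 2-methoxyphenyl on a saturated chain carbon bound to a nitrogen on an aromatic ring. Here 3-methoxyphenyl takes the place of 2-methoxyphenyl, on a saturated chain carbon bound to a nitrogen on an aromatic ring.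

For the measured compounds named here, only one measured step bears on this change, because it alters the same place: a step that the two limits leave unreadable from compound 1 to compound 2. Its size cannot be read, so it gives no number to carry over to the new compound. What it does show is that two different groups at this place both end at a limit. The expectation is therefore no change beyond the usual scatter of this assay, and the estimated step is a number no higher from compound 2 to compound 3 (the limit leaves the size open). Compound 3 is estimated at 100000 nM, with an expected range from 30000 nM to 200000 nM, and will most likely be reported as a limit again.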

Compound 3, half-maximal inhibitory concentration: 97000 nM
Compound 3: the middle estimate sits 1.0-fold (0.01 log units) above what was measured; the measured number falls inside the stated range.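

For the compounds shown here, with compound 3 this position gives a number rather than a limit for the first time: in this assay compound 3 gives 97000 nM. Putting 3-methoxyphenyl in place of 2-methoxyphenyl gives an at least 1.0-fold lower number from compound 2 to compound 3 (0.01 log units; that floor lies within the scatter), and putting methyl in place of hydrogen on the oxygen gives an at least 1.0-fold lower number from compound 1 to compound 3 (0.01 log units; that floor lies within the scatter); each figure is only a floor, so neither change can be said to do more than stay within the normal spread of repeated measurements. The true size of both steps stays hidden, and the step between the other two compounds cannot be read at all, because those two compounds still end at a limit: the limit of > 100000 nM in this assay, at which 2 of the 3 values shown sit.

As far as these compounds go, all three compounds carry a phenyl ring with a single hydroxy or methoxy group, so it remains open whether any group at this place can bring the number clearly down in this assay. An amine or a carboxylic acid on that ring, or a longer chain in place of the single saturated chain carbon, would be a different kind of change, and the compounds shown say nothing about how either would behave.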